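From compound 2 to compound 3: replacing a phenyl group

The source may report more compounds than this note shows. Statements on the series, on what has been measured and on what is new or still open speak of the compounds shown alone.

Compounds measured so far in an ADME assay on HT-29 cells (Homo sapiens) for cytotoxicity, read by MTT assay, with a stated time of 72 h; a lower number here means a stronger inhibitor, a higher number a weaker inhibitor
- compound 1 `COc1cc(C2=C(c3cc(C)c(OC)c(C)c3)C(OC(C)=O)CC2=O)cc(OC)c1OC` gives > 100 ug/mL
- compound 2 `COc1cc(C2=C(c3ccccc3)C(O[SiH2]C(C)(C)C)CC2=O)cc(OC)c1OC` gives > 100 ug/mL

Compound 2 stands at the limit of > 100 ug/mL in this assay, at which 2 of the 2 values shown sit, and this is a limit of the assay, not a number. Compound 3 `COc1cc(C2=C(c3cc(C)c(OC)c(C)c3)C(O[SiH2]C(C)(C)C)CC2=O)cc(OC)c1OC` has not yet been measured. It has 4-methoxy-3,5-dimethylphenyl in place of phenyl on a double-bonded ring carbon. Compound 1 already carries 4-methoxy-3,5-dimethylphenyl and shows > 100 ug/mL as a limit too. In this assay the expected change is a number no higher from compound 2 to compound 3 (the limit leaves the size open) and nothing beyond the scatter is expected. The value estimated for compound 3 is 100 ug/mL with an expected range from 40 ug/mL to 200 ug/mL and a good chance of only a limit.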

Compound 3, half-maximal inhibitory concentration: 10 ug/mL
Compound 3: the middle estimate sits 10-fold (1.00 log units) above what was measured; the whole stated range lies above it.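

In this assay, the double-bonded ring carbon is a place where a change can count: 4-methoxy-3,5-dimethylphenyl in place of phenyl gives an at least 10-fold lower number from compound 2 to compound 3 (1.00 log units; beyond the scatter). That group does not do this alone: the group of 5 heavy atoms in place of the group of 3 heavy atoms on the oxygen gives an at least 10-fold lower number from compound 1 to compound 3 (1.00 log units; beyond the scatter), so a measurable number appears only with both groups present. Both sizes are minimums, as each starting value is a limit of the assay, not a number: the limit of > 100 ug/mL in this assay, at which 2 of the 3 values shown sit.

As far as these compounds go, it remains open which part of 4-methoxy-3,5-dimethylphenyl matters, the methoxy or the two methyl groups. Also open, from the compounds shown here alone, is how an amine or a carboxylic acid on that aromatic ring would behave.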